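Swapping the aryl group on a naphthyloxy hydrazone

The source may hold more compounds than are shown below. What is called first, only, known or untested is meant among the compounds shown, and "the series" means these compounds.

Measured in an ADME assay on HEL cells (Homo sapiens) for cytotoxicity; on this read-out lower numbers stand for higher toxicity in this test and higher numbers for lower toxicity in this test:
Compound 1 `C/C(=N\NC(=O)COc1cccc2ccccc12)c1cccc([N+](=O)[O-])c1`: 10.5 ug/mL
Compound 2 `O=C(COc1cccc2ccccc12)N/N=C/C=C/c1ccccc1`: 100 ug/mL
Compound 3 `O=C(COc1cccc2ccccc12)N/N=C/c1cccc([N+](=O)[O-])c1`: 61.2 ug/mL

Compound 1 stands lowest of these three on this assay. Compound 3 is its nearest neighbour and compound 2 its furthest, and both lie beyond the usual scatter from it.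

The next compound is compound 4 `C/C(=N\NC(=O)COc1cccc2ccccc12)c1ccc(Cl)cc1`, which carries 4-chlorophenyl in place of 3-nitrophenyl on a carbon with a double bond to nitrogen. Within the data shown here, no measured pair shows this exchange, so its size cannot be read directly from the data. The expectation rests on the starting point alone: compound 1 at 10.5 ug/mL sits under the other two measured compounds, so a rise is thought likelier than a fall. A moderate upward move is expected, a 1.9-fold higher number from compound 1 to compound 4 (0.28 log units; within the scatter), though it may not clear the scatter. For compound 4 the estimate is 20 ug/mL, with an expected range from 7 ug/mL to 60 ug/mL.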

Compound 4, half-maximal cytotoxic concentration: 7.1 ug/mL
The estimate for compound 4 lay 2.8-fold (0.45 log units) above the measured number, within the range that was stated.
By their numbers in this assay, from the lowest: compounds 4 and 1 (each within the scatter of the next); then compounds 3 and 2 (each within the scatter of the next).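

In this assay, among these compounds, the exchange of 3-nitrophenyl for 4-chlorophenyl on a carbon with a double bond to nitrogen gives a 1.5-fold lower number from compound 1 to compound 4 (0.17 log units; within the scatter) and is the first change at this position that can be read directly. In this pair, a phenyl ring carrying chlorine in place of one carrying a nitro group leaves the number within the scatter, so the nitro group is not required for the low number seen with compound 1. Nothing available explains this result.

From the compounds shown here alone, whether an amine or a carboxylic acid on the phenyl ring would leave the number equally low remains open. So does the effect of a longer chain in place of the saturated chain carbon on that same carbon.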